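Sulfonylamino in place of dipropylamino: outlook for compound 4

A few compounds are considered here, and "the series" means these few. Any claim that something is new, unique, unknown or untested is made for them only; others in the source may bear on it.

Compound 3 `CCCN(CCC)c1nc(-c2ccc(OCC)cc2)c(-c2cc(OC)c(OC)c(OC)c2)s1` is characterised in a functional assay on HepG2 cells (Homo sapiens) for antiproliferative activity, read by MTT assay, with a stated time of 48 h (a lower number here means a stronger inhibitor, a higher number a weaker inhibitor), only by a limit, not a number: compound 3 gives > 5000 nM. Compound 2 `C=CCN(CC=C)c1nc(-c2ccc(OCC)cc2)c(-c2cc(OC)c(OC)c(OC)c2)s1` is also known only as a limit, giving > 5000 nM. The step that the two limits leave unreadable from compound 2 to compound 3 therefore has no readable size. Compound 1 `CCOc1ccc(-c2nc(NS(=O)(=O)c3ccc(OC)c(F)c3)sc2-c2cc(OC)c(OC)c(OC)c2)cc1` likewise reaches only a limit, giving > 5000 nM. Nothing separates the three on the numbers shown; all sit at the limit of > 5000 nM in this assay, at which 3 of the 3 values shown sit.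

Compound 4 `CCOc1ccc(-c2nc(NS(=O)(=O)c3ccc(C)c(C)c3)sc2-c2cc(OC)c(OC)c(OC)c2)cc1` differs from compound 3 in one place: ((3,4-dimethylphenyl)sulfonyl)amino in place of dipropylamino on an aromatic carbon. For the measured compounds named here, no measured step bears on this change directly. The nearest point of comparison is compound 1, which carries a sulfonylamino group of its own at the same place, and compound 1 gives only a limit. With compound 3 at the limit and compound 1 at the limit, the step that the limit leaves unreadable from compound 3 to compound 4 is expected to be none readable, and the most likely outcome for compound 4 is again a limit rather than a number.

Compound 4 is estimated at 9000 nM in this assay, within a range of 3000 nM to 40000 nM, with a better chance than not that only a limit is reported.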

Compound 4, half-maximal inhibitory concentration: > 5000 nM
Compound 4: a limit, no number (the forecaster's own chance of this, stated with the estimate: 75%); the middle value does not contradict the limit.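

In this assay compound 4 gives > 5000 nM, a limit and not a number. No step from compound 1, compound 2 or compound 3 to compound 4 can be read, because all four compounds stand at the same limit: the limit of > 5000 nM in this assay, at which 4 of the 4 values shown sit.

The compounds shown leave open whether a change at this place, or on the sulfonyl sulfur, separates any of them in this assay.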